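Series notes: isopropyl in place of 3-methylphenyl

The compounds below may be only part of what the source reports. "The series", "measured", "known", "first", "only" and "open" are said of these compounds alone.

Compound 1 `CCCCNC(=S)N/N=C\c1c[nH]c2ccccc12` carries a butyl group on the amide-type nitrogen. In an ADME assay on KB cells (Homo sapiens) for cytotoxicity, read by MTT assay, with a stated time of 44 h (on this read-out lower numbers stand for stronger inhibition and higher numbers for weaker inhibition), compound 1 gives only a limit, > 100000 nM. Compound 2 `Cc1cccc(NC(=S)N/N=C\c2c[nH]c3ccccc23)c1` carries 3-methylphenyl on that nitrogen. In this assay compound 2 likewise gives only a limit, > 100000 nM. Compound 3 `Fc1cccc(F)c1NC(=S)N/N=C\c1c[nH]c2ccccc12` carries a difluorinated phenyl group on that nitrogen. In this assay compound 3 also gives only a limit, > 100000 nM. The step that the two limits leave unreadable from compound 1 to compound 2 is accordingly not readable. Compound 2 thus stands at the limit (the limit of > 100000 nM in this assay, at which 3 of the 3 values shown sit).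

Compound 4 `CC(C)NC(=S)N/N=C\c1c[nH]c2ccccc12` differs from compound 2 by isopropyl in place of 3-methylphenyl on an amide-type nitrogen. Going by the values given here, the only measured step at this nitrogen, a step that the two limits leave unreadable from compound 1 to compound 2, exchanges a chain for an aromatic ring and so bears on the present change, but its size is hidden by the two limits. Nothing measured separates chain from ring at this position. Compound 4 is therefore expected to sit at the limit as well, with an expected step that the limit leaves unreadable from compound 2 to compound 4 not beyond the scatter. The estimate for compound 4 is 200000 nM, with a range from 50000 nM to 1000000 nM.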

Compound 4, half-maximal inhibitory concentration: > 100000 nM
Compound 4: a limit, no number; the forecaster's own chance of this, stated with the estimate: 85%; the middle value is on the limit's open side.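

In this assay compound 4 gives only a limit, > 100000 nM, so its steps from compound 1 and from compound 2 cannot be read. The compounds shown leave open whether the groups on the amide-type nitrogen differ at all in cytotoxicity, with every value at the same limit: the limit of > 100000 nM in this assay, at which 4 of the 4 values shown sit.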